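Replacing the Urea Terminus with a Tetrazole Ring

The compounds below may be only part of what the source reports. "The series", "measured", "known", "first", "only" and "open" are said of these compounds alone.

Three compounds share one core and differ only at the tip of the biaryl arm. In a functional assay (Pituitary gland cell) with Rattus norvegicus as the target (a lower number here means that less compound is needed, a higher number that more compound is needed for the effect), compound 1 `CC(C)(N)C(=O)N[C@@H]1CCc2ccccc2N(Cc2ccc(-c3ccccc3CNC(N)=O)cc2)C1=O` gives 21 nM. Compound 2 `CC(C)(N)C(=O)N[C@@H]1CCc2ccccc2N(Cc2ccc(-c3ccccc3CNC(=O)NC3CC3)cc2)C1=O` gives 45 nM in this assay, and compound 3 `CN(C)C(=O)NCc1ccccc1-c1ccc(CN2C(=O)[C@H](NC(=O)C(C)(C)N)CCc3ccccc32)cc1` gives 60 nM in this assay. Compound 3 stands highest of the three numbers: the step of a 2.9-fold higher number from compound 1 to compound 3 (0.46 log units; beyond the scatter) lies beyond the scatter, whereas the step of a 1.3-fold higher number from compound 2 to compound 3 (0.12 log units; within the scatter) does not. The step of a 2.1-fold higher number from compound 1 to compound 2 (0.33 log units; beyond the scatter) points the same way as the first.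

Compound 4 `CC(C)(N)C(=O)N[C@@H]1CCc2ccccc2N(Cc2ccc(-c3ccccc3-c3nn[nH]n3)cc2)C1=O` carries a different kind of change: 2H-tetrazol-5-yl in place of ((dimethylcarbamoyl)amino)methyl on an aromatic carbon. Within the data shown here, none of the measured steps covers this exchange; each of them only alters the substituent on the urea nitrogen, and each moved the number by a modest amount or stayed within the scatter. Among the measured compounds shown here, the tetrazole exchange removes the urea and its connecting methylene altogether, so its direction cannot be read from this series, and the measured steps suggest only that changes at this tip have not moved the number far. Compound 4 is therefore expected to give 70 nM in this assay, with a range from 15 nM to 300 nM. The estimated step of a 1.2-fold higher number from compound 3 to compound 4 (0.07 log units; within the scatter) is expected to stay within the scatter.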

Compound 4, concentration for half-maximal effect: 30 nM
Compound 4: middle estimate off by 2.3-fold (0.37 log units), on the high side, and the stated range covers the measured number.
By their numbers in this assay, from the lowest: compounds 1, 4, 2 and 3 (each within the scatter of the next, the first and the last beyond it).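

In this assay, among these compounds, the earlier compounds varied only the substituent on the urea nitrogen, whereas compound 4 shows that the entire arm tip can be exchanged on this aromatic carbon without a step beyond the scatter from any of the three ureas (a 2.0-fold lower number from compound 3 to compound 4 (0.30 log units; within the scatter); a 1.5-fold lower number from compound 2 to compound 4 (0.18 log units; within the scatter); a 1.4-fold higher number from compound 1 to compound 4 (0.15 log units; within the scatter)). Although compound 1 and compound 3 are separated beyond the scatter, compound 4 lies within the scatter of both, so among these four compounds a urea is not needed for a number of this size, and 2H-tetrazol-5-yl, a single five-membered aromatic ring with 4 hetero atoms, serves in its place. Nothing given here explains why the urea groups and the tetrazole give such similar numbers.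

The compounds shown leave open whether a carboxylic acid or a methyl-substituted tetrazole on the same aromatic carbon would stay in this range. They also leave open whether a tetrazole attached through a methylene, as the ureas are, would give a number like that of compound 4.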